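A few compounds are considered here, and "the series" means these few. Any claim that something is new, unique, unknown or untested is made for them only; others in the source may bear on it.

In an ADME assay on MRC5 cells (Homo sapiens), read by MTT assay, with a stated time of 72 h (on this read-out higher numbers stand for weaker inhibition and lower numbers for stronger inhibition), compound 1 `COc1ncnc2c1c(-c1ccccc1)cn2[C@@H]1O[C@H](CO)[C@@H](O)[C@H]1O` gives > 100000 nM, which is a limit of the assay and not a measured number. Compound 1 therefore sits at the top of the scale, at the limit of > 100000 nM in this assay, at which 2 of the 3 values shown sit. Compound 2 `COc1ncnc2c1c(-c1cc3ccccc3o1)cn2[C@@H]1O[C@H](CO)[C@@H](O)[C@H]1O`, with 1-benzofuran-2-yl in place of phenyl on an aromatic carbon, gives 65600 nM. That change amounts to an at least 1.5-fold lower number from compound 1 to compound 2 (0.18 log units; that floor lies within the scatter), so it gives no clear shift. Compound 3 `CSc1ncnc2c1c(-c1ccsc1)cn2[C@@H]1O[C@H](CO)[C@@H](O)[C@H]1O` already carries methylsulfanyl, though with a different group where compound 1 has phenyl, and compound 3 gives > 100000 nM, which is also a limit.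

The next compound is compound 4 `CSc1ncnc2c1c(-c1ccccc1)cn2[C@@H]1O[C@H](CO)[C@@H](O)[C@H]1O`, where methylsulfanyl takes the place of methoxy on an aromatic carbon: methylsulfanyl in place of methoxy on an aromatic carbon. Among the compounds with values here, no measured pair isolates this swap. The nearest guide is compound 3 at > 100000 nM, a limit that shows methylsulfanyl can occur in a compound with no measurable effect in this assay. Within the data shown here, the one measured step, an at least 1.5-fold lower number from compound 1 to compound 2 (0.18 log units; that floor lies within the scatter), involves a different position and offers only indirect support. No step beyond the scatter is therefore expected, and the result may well be reported only as a limit. The estimated change is a number no higher from compound 1 to compound 4 (the limit leaves the size open). For compound 4 the expected value is 100000 nM, within an estimated range of 40000 nM to 200000 nM.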

Compound 4, half-maximal inhibitory concentration: > 100000 nM
Compound 4 was reported as a limit; the forecaster's own chance of this, stated with the estimate: 65%; the middle value sits exactly at the limit.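

In this assay compound 4 gives > 100000 nM, which is a limit of the assay. Within the data shown here, compound 1 and compound 3 also sit at that limit, so no step to compound 4 can be read from either: the limit of > 100000 nM in this assay, at which 3 of the 4 values shown sit. The compounds shown leave open whether methylsulfanyl in place of methoxy on an aromatic carbon changes this read-out at all.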